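Same atoms, joined differently: compound 3 to compound 4

A few compounds are considered here, and "the series" means these few. Any claim that something is new, unique, unknown or untested is made for them only; others in the source may bear on it.

Series values in a physicochemical assay for lipophilicity, using the shake flask method; a lower number here means a more polar compound, a higher number a more lipophilic compound:
compound 1 `CC(C)Oc1cc(Oc2ccc(S(C)(=O)=O)cc2)cc(-c2ccnc(=O)[nH]2)c1`: "not determined" (no result reported)
compound 2 `CC(C)Oc1cc(Oc2ccc(S(C)(=O)=O)cc2)cc(-c2nccc(=O)[nH]2)c1`: 2.14
compound 3 `Cc1cnc(-c2cc(Oc3ccc(S(C)(=O)=O)cc3)cc(OC(C)C)c2)[nH]c1=O`: 2.68
compound 4 `Cc1cc(=O)[nH]c(-c2cc(Oc3ccc(S(C)(=O)=O)cc3)cc(OC(C)C)c2)n1`: not yet measured

Compound 3, at 2.68, holds the higher of the two numbers in this assay. Compound 2 lies lower, beyond the scatter, and compound 1 offers no number for comparison.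

The structural change to compound 4 is a group of 8 heavy atoms (5 carbon, 2 nitrogen, 1 oxygen; one six-membered aromatic ring with 2 hetero atoms) in place of a group of 8 heavy atoms (5 carbon, 2 nitrogen, 1 oxygen; one six-membered aromatic ring with 2 hetero atoms), on an aromatic carbon. The two compounds have the same atoms, joined differently, and the exchanged group sits on an aromatic carbon of a six-membered aromatic ring of carbon only.

Going by the values given here, one measured step bears on this change: a number 0.54 log units higher from compound 2 to compound 3 (beyond the scatter), which is modest and beyond the scatter, with methyl in place of hydrogen on an aromatic carbon. That step adds a methyl, whereas the change to compound 4 adds no atoms, so its size does not carry over directly. Among the compounds with values here, no measured pair shows a change of this kind, and the evidence is thin. The expectation therefore starts from compound 3 at 2.68, with no shift beyond the scatter in either direction. The estimated step is a number 0.08 log units lower from compound 3 to compound 4 (within the scatter). For compound 4 the expected value is 2.6, with an estimated range from 2.2 to 3.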

Compound 4, distribution coefficient: 2.43
Beside the measured number, compound 4's estimate is 0.17 log units above it, and the stated range covers the measured number.
By their numbers in this assay, from the lowest: compounds 2, 4 and 3 (each within the scatter of the next, the first and the last beyond it).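

Exchanging the six-membered aromatic ring with 2 hetero atoms for its isomer, which moves the methyl to another ring carbon, gives a number 0.25 log units lower from compound 3 to compound 4 (within the scatter) in this assay. Going by these compounds alone, this is the first reading of a change that adds no atoms, and at this size the two methyl placements cannot be told apart. Methyl in place of hydrogen gives a number 0.54 log units higher from compound 2 to compound 3 (beyond the scatter) in one placement and a number 0.29 log units higher from compound 2 to compound 4 (within the scatter) in the other, so only the first of these placements stands clear of compound 2, and no measurement at hand accounts for this.

On these data alone, it remains open whether an ethyl group, an amine or a carboxylic acid on either of these two ring carbons would stay as close to compound 2 as compound 4 does or stand as far from it as compound 3 does. In this assay compound 1 gives "not determined" (no result reported), so its arrangement of the ring stays outside any comparison with the other three.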